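Bromo in Place of Fluoro on the Shared Core

The source may hold more compounds than are shown below. What is called first, only, known or untested is meant among the compounds shown, and "the series" means these compounds.

Going by the values given here, compound 1 `COc1cc(C(=O)c2sc(-c3ccc(F)cc3)cc2N)cc(OC)c1OC` gives the lowest number of the two so far measured in a functional assay on MOLT-4 cells (Homo sapiens) for antiproliferative activity (a lower number here means a stronger inhibitor, a higher number a weaker inhibitor), at 12 nM. Compound 2 `COc1cc(C(=O)c2sc(-c3ccc(Cl)c(Cl)c3)cc2N)cc(OC)c1OC` gives 270 nM, and the step of a 23-fold higher number from compound 1 to compound 2 (1.35 log units; beyond the scatter) is the only one measured. Compound 3 `COc1cc(C(=O)c2sc(-c3ccc(Br)cc3)cc2N)cc(OC)c1OC` differs from compound 1 by bromo in place of fluoro on an aromatic carbon. The measured step changes the halogen pattern more broadly than this single exchange does, so it bears on it only loosely; a modest rise, perhaps beyond the scatter, seems plausible but far from certain. Compound 3 is therefore expected to give 30 nM, within 10 nM to 90 nM, a step of a 2.5-fold higher number from compound 1 to compound 3 (0.40 log units; beyond the scatter).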

Compound 3, half-maximal inhibitory concentration: 92 nM
Estimate against measurement, compound 3: 3.1-fold (0.49 log units) below; measured number above the stated range.
By their numbers in this assay, from the lowest: compound 1; then compound 3; then compound 2.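

In this assay, the exchange of a single halogen on the shared core, with nothing else altered, already carries a clear penalty: a 7.7-fold higher number from compound 1 to compound 3 (0.88 log units; beyond the scatter). That penalty does not account for the whole loss seen with 3,4-dichlorophenyl, since the 4-bromophenyl group recovers part of it, with a 2.9-fold lower number from compound 2 to compound 3 (0.47 log units; beyond the scatter). Nothing measured here explains these differences.

The compounds shown leave open how a lone chloro would rank at this place. They also leave open whether a methyl, a nitrile or an amine there would keep the number of compound 1.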